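From hydroxy to methoxycarbonyl: expecting compound 4

The source may hold more compounds than are shown below. What is called first, only, known or untested is meant among the compounds shown, and "the series" means these compounds.

Values in a functional assay on MKN-45 cells (Homo sapiens) for antiproliferative activity; a lower number here means a stronger inhibitor, a higher number a weaker inhibitor
- Compound 1 `COc1ccc(S(=O)(=O)N2CCc3cccc(Nc4ccc(O)cc4)c32)cc1` gives 493 nM
- Compound 2 `COc1ccc(S(=O)(=O)N2CCc3cccc(Nc4ccc(F)c(F)c4)c32)cc1` gives 726 nM
- Compound 3 `COc1ccc(S(=O)(=O)N2CCc3cccc(Nc4ccc(C#N)cc4)c32)cc1` gives 92 nM

Compound 1 stands at the upper end of these three numbers, level with compound 2 within the scatter, as a 1.5-fold higher number from compound 1 to compound 2 (0.17 log units; within the scatter) shows. Compound 3 lies clearly lower. Compound 4 `COC(=O)c1ccc(Nc2cccc3c2N(S(=O)(=O)c2ccc(OC)cc2)CC3)cc1` has not yet been measured. It carries methoxycarbonyl in place of hydroxy on an aromatic carbon, para to a large group (methoxycarbonyl in place of hydroxy on an aromatic carbon).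

The nearest guide is compound 3, with a 5.4-fold lower number from compound 1 to compound 3 (0.73 log units; beyond the scatter), since cyano entered at that same place. Compound 2 goes against any simple rule that replacing the 4-hydroxyphenyl lowers the number, and a 7.9-fold lower number from compound 2 to compound 3 (0.90 log units; beyond the scatter) shows how much depends on the group that enters. A step in the direction of compound 3 therefore seems likely, though a smaller one. The expected step is a 2.5-fold lower number from compound 1 to compound 4 (0.39 log units; beyond the scatter). For compound 4 the estimated value in this assay is 200 nM, with an expected range from 70 nM to 600 nM.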

Compound 4, half-maximal inhibitory concentration: 487 nM
The estimate for compound 4 lay 2.4-fold (0.39 log units) below the measured number; the range from low to high includes it.
By their numbers in this assay, from the lowest: compound 3; then compounds 4, 1 and 2 (each within the scatter of the next).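

In this assay, methoxycarbonyl on this aromatic carbon, para to a large group, stays level with hydroxy (a 1.0-fold lower number from compound 1 to compound 4 (0.01 log units; within the scatter)), so the drop seen with cyano does not extend to every group that replaces hydroxy here. Cyano and methoxycarbonyl, though they enter at the same place and neither has a hydrogen-bond donor, stand clearly apart (a 5.3-fold higher number from compound 3 to compound 4 (0.72 log units; beyond the scatter)), while the 4-(methoxycarbonyl)phenyl and 3,4-difluorophenyl groups stay level (a 1.5-fold lower number from compound 2 to compound 4 (0.17 log units; within the scatter)), leaving compound 3 alone at the low end of these four. Nothing available accounts for the gap between cyano and methoxycarbonyl.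

On these data alone, whether a carboxylic acid, a primary amide or an acetyl group at this place would fall with cyano or with methoxycarbonyl remains open. So does whether a longer ester chain would stay level with methoxycarbonyl.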